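This account rests on a few compounds, and the source may have more. Where it says the series, first, only, none or still open, it means among the compounds named here.

Compound 1 `OC[C@H]1OC(n2cnc3c(Nc4ccccc4)nccc32)[C@H](O)[C@@H]1O`: in a functional assay on the whole organism (Pleural cavity) with Rattus norvegicus as the target (on this read-out lower numbers stand for an effect already at smaller amounts and higher numbers for an effect only at larger amounts of compound), compound 1 gives only a limit, > 9 mg/kg.
Compound 2 `OC[C@H]1OC(n2cnc3c(NCc4ccccc4)nccc32)[C@H](O)[C@@H]1O`: in this assay compound 2 also gives only a limit, > 9 mg/kg.
Compound 3 `OC[C@H]1OC(n2cnc3c(S)nccc32)[C@H](O)[C@@H]1O`: in this assay compound 3 gives 9 mg/kg.

Compound 3 is the only one of the three with a number rather than a limit, and its number stands at the same level as the limit the other two reach, (the limit of > 9 mg/kg in this assay, at which 2 of the 3 values shown sit). The unmeasured compound 4 `OC[C@H]1OC(n2cnc3c(SCc4ccccc4)nccc32)[C@H](O)[C@@H]1O` comes from compound 3 by the change (benzyl in place of hydrogen on a sulfur), read one bond further out as sulfanyl to benzylsulfanyl. Going by the values given here, no measured step adds a benzyl on a sulfur, so the nearest comparisons are the steps that involve a benzyl on nitrogen: a step that the two limits leave unreadable from compound 1 to compound 2 and a number no higher from compound 2 to compound 3 (the limit leaves the size open). Both are masked by limits, so their size cannot be read. What the values show is that the two compounds bearing an aromatic ring on the core were not active within the dose range used, while compound 3, bearing only hydrogen on its sulfur, was. Adding a benzyl is therefore expected to leave the effect unchanged or to push it to larger amounts, with no numerical guide for how far. Compound 4 is estimated at 13 mg/kg, range 6 mg/kg to 30 mg/kg, a step of a 1.4-fold higher number from compound 3 to compound 4 (0.16 log units; within the scatter) in this assay, and a limit instead of a number is considered quite likely.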

Compound 4, dose for half-maximal effect: 9 mg/kg
Estimate against measurement, compound 4: 1.4-fold (0.16 log units) above, and the stated range covers the measured number.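

In this assay, placing a benzyl on the sulfur gives no change at the digits printed from compound 3 to compound 4 (within the scatter). Going by these compounds alone, this is the first pair that isolates a change at this sulfur, and it shows that the sulfur, bound to an aromatic carbon, can carry a benzyl in place of its hydrogen with no measurable shift in the dose needed. The data also give a number no higher from compound 2 to compound 4 (the limit leaves the size open) and a number no higher from compound 1 to compound 4 (the limit leaves the size open) as steps whose size cannot be read, because each starts from a limit, not a number: the limit of > 9 mg/kg in this assay, at which 2 of the 4 values shown sit.

Going by these compounds, it remains open how a smaller group on the sulfur, such as methyl, or a longer chain would behave. Also unresolved is whether an amine or a carboxylic acid at the end of such a chain would move the value beyond the usual scatter.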